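Cytotoxicity notes on the shared-core set, compounds 1 to 4

The compounds below may be only part of what the source reports. "The series", "measured", "known", "first", "only" and "open" are said of these compounds alone.

Measured so far in an ADME assay on CCRF-HSB-2 cells (Homo sapiens) for cytotoxicity, with a stated time of 7 days; on this read-out higher numbers stand for lower toxicity in this test and lower numbers for higher toxicity in this test:
compound 1 `Nc1nc(OCC(F)(F)F)c2ncn(/C=C3/CC3(CO)CO)c2n1` — > 20000 nM, a limit of the assay
compound 2 `CC(C)CSc1nc(N)nc2c1ncn2/C=C1/CC1(CO)CO` — 60000 nM
compound 3 `Nc1nc(NC2CC2)c2ncn(/C=C3/CC3(CO)CO)c2n1` — > 20000 nM, a limit of the assay

Compound 3 stands at a limit in this assay and not at a number. Two of the three values shown sit at that same limit: the limit of > 20000 nM in this assay, at which 2 of the 3 values shown sit. Compound 2 alone gives a number, and the steps among the three measured compounds cannot be read: a step that the limit leaves unreadable from compound 1 to compound 2, a step that the limit leaves unreadable from compound 2 to compound 3, a step that the two limits leave unreadable from compound 1 to compound 3. None of them has a readable size, so nothing can be said about how the group on that aromatic carbon shifts cytotoxicity in this assay.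

Compound 4 `CCCOc1nc(N)nc2c1ncn2/C=C1/CC1(CO)CO` differs from compound 3 in one place: propoxy in place of cyclopropylamino on an aromatic carbon. Among the measured compounds shown here, no measured step speaks to this exchange; the unreadable steps above are the only comparisons at the same aromatic carbon, and all three measured compounds show low toxicity in this assay. The step that the limit leaves unreadable from compound 3 to compound 4 is therefore expected to stay within the scatter. Compound 4 is expected at about 40000 nM, with a range from 15000 nM to 120000 nM, and is most likely to be reported again only as a limit.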

Compound 4, half-maximal cytotoxic concentration: > 20000 nM
Compound 4: a limit, no number; the forecaster's own chance of this, stated with the estimate: 65%; the middle value is on the limit's open side.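

In this assay compound 4 gives > 20000 nM, a limit of the assay. No new step can be read from this result, as the steps to compound 4 from compound 1, compound 2 and compound 3 all remain without a size: the limit of > 20000 nM in this assay, at which 3 of the 4 values shown sit.

Left open is whether the group on that aromatic carbon shifts cytotoxicity in this assay at all, and by how much.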